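Removing the acylurea from a trifluoromethyl-bearing core

The compounds below may be only part of what the source reports. "The series", "measured", "known", "first", "only" and "open" are said of these compounds alone.

Compound 1: `CNc1nc(C)c(C(=O)N/N=C/c2ccc(C(F)(F)F)cc2)s1`, > 100 ug/mL
Compound 2: `CN(C(=O)NC(=O)c1ccccc1F)c1nc(C(F)(F)F)c(C(=O)N/N=C/c2ccc(C(F)(F)F)cc2)s1`, 3.87 ug/mL

Both compounds were tested in a functional assay on BCG823 cells (Homo sapiens) for inhibition, read by MTT assay, with a stated time of 72 h; on this read-out higher numbers stand for weaker inhibition and lower numbers for stronger inhibition. Compound 1 gives > 100 ug/mL, which is a limit of the assay rather than a number. Going by the values given here, compound 2 gives 3.87 ug/mL, the only actual number among the two values. Among the compounds with values here, compound 2 therefore stands alone as the measured point; the other result is the limit of > 100 ug/mL in this assay, at which 1 of the 2 values shown sits, so no measured step between two numbers exists.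

Compound 3 is `CNc1nc(C(F)(F)F)c(C(=O)N/N=C/c2ccc(C(F)(F)F)cc2)s1`. Its change from compound 2 is hydrogen in place of ((2-fluorophenyl)carbonyl)carbamoyl on a nitrogen on an aromatic ring. Within the data shown here, no measured step covers a change of this kind, so the expectation rests on the two values alone. Compound 1 sits at a limit, and compound 3 shares with it a hydrogen on that ring nitrogen, so weak inhibition is expected. Compound 3 is expected to give about 60 ug/mL, within 15 ug/mL to 200 ug/mL. That estimate means a step of a 16-fold higher number from compound 2 to compound 3 (1.19 log units; beyond the scatter) toward weaker inhibition, and a fair chance that only a limit is reported.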

Compound 3, half-maximal inhibitory concentration: > 100 ug/mL
Compound 3: only a limit was reported; the forecaster's own chance of this, stated with the estimate: 55%; at least 1.6-fold (0.22 log units) between middle value and limit.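

In this assay, replacing the ((2-fluorophenyl)carbonyl)carbamoyl group on the nitrogen with hydrogen gives an at least 25-fold higher number from compound 2 to compound 3 (1.41 log units; beyond the scatter), so among the compounds shown, a measurable value appears only where that group is present. Trifluoromethyl in place of methyl on the aromatic carbon is not enough on its own to bring back a measurable value: compound 3 gives > 100 ug/mL, which is a limit of the assay. The step from compound 1 to compound 3 cannot be read, and the step from compound 2 is only a minimum, since the true values behind these limits are unknown: the limit of > 100 ug/mL in this assay, at which 2 of the 3 values shown sit.

The compounds shown leave open which part of the lost group matters, whether the fluorine, the phenyl ring or the carbonyl-containing link, and a plain acetyl group or an unsubstituted benzoyl urea on that nitrogen would help to separate these parts. They also leave open whether the trifluoromethyl group matters once the ((2-fluorophenyl)carbonyl)carbamoyl group is in place, which the same compound carrying methyl on the aromatic carbon could show.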